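A chloro to methoxy swap on compound 1

The compounds below may be only part of what the source reports. "The series", "measured", "known", "first", "only" and "open" are said of these compounds alone.

Compound 1 `O=C1COc2ccc(-c3cccc(NS(=O)(=O)c4ccc(F)cc4)c3)cc2N1c1ccc(Cl)cc1` gives 39800 nM
Compound 2 `COc1ncc(-c2ccc3c(c2)N(C2CC2)C(=O)CO3)cc1NS(=O)(=O)c1ccc(F)cc1` gives 35200 nM

In a functional assay on MCF7 cells (Homo sapiens) for antiproliferative activity, read by MTT assay, with a stated time of 72 h (on this read-out lower numbers stand for stronger inhibition and higher numbers for weaker inhibition), compound 1 reads 39800 nM and compound 2 reads 35200 nM so the two lie within the usual scatter of each other and cannot be ranked. Within the data shown here, with only two numbers so far, compound 1 has little to be placed against.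

The next compound to be tested is compound 3 `COc1ccc(N2C(=O)COc3ccc(-c4cccc(NS(=O)(=O)c5ccc(F)cc5)c4)cc32)cc1` which keeps the core of compound 1 and changes it in one place only. The difference is methoxy in place of chloro on an aromatic carbon. The same change can be read as 4-chlorophenyl to 4-methoxyphenyl, and it sits para to a large group.

Among the measured compounds shown here, no two measured compounds differ in just one place, so nothing here shows how strongly this spot responds to change. The expectation therefore stays close to compound 1 at 39800 nM with no firm direction and no step beyond the scatter. The estimated step is a 1.1-fold lower number from compound 1 to compound 3 (0.06 log units; within the scatter) (an expectation, not a measurement). Compound 3 is expected to read 35000 nM (estimated range 14000 nM to 80000 nM).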

Compound 3, half-maximal inhibitory concentration: 32400 nM
Beside the measured number, compound 3's estimate is 1.1-fold (0.03 log units) above it, and the stated range covers the measured number.
By their numbers in this assay, from the lowest: compounds 3, 2 and 1 (each within the scatter of the next).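

In this assay, placing methoxy where chloro stood gives a 1.2-fold lower number from compound 1 to compound 3 (0.09 log units; within the scatter), so the two compounds cannot be ranked. Among these compounds, this is the first pair that differs in just one place, and it gives a first look at how this position responds: going from 4-chlorophenyl to 4-methoxyphenyl, which adds a hydrogen-bond acceptor on an aromatic carbon para to a large group, produces no step that can be told apart from the noise of repeated measurements. No measurement is available that would link this outcome to any property of either group.

A single swap cannot show whether this position is insensitive to change in general or whether these two groups simply happen to give similar readings, so an amine or a carboxylic acid on the same carbon remains an open test. From the compounds shown here alone, it also remains open whether a change elsewhere on the core of compound 1 would move the number beyond the scatter, since this pair speaks only to this one position.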